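A few compounds are considered here, and "the series" means these few. Any claim that something is new, unique, unknown or untested is made for them only; others in the source may bear on it.

Compound 1 `Cc1cc(CN(CC2CCCC2)C(CC(=O)O)c2ccc(Cl)cc2)ccc1OCCN1C(=O)CCC1=O`: 52%
Compound 2 `Cc1cc(CN(CC2CCCC2)[C@@H](CC(=O)O)c2ccc(Cl)cc2)ccc1OCCN1C(=O)CCC1=O`: 69%
Compound 3 `Cc1cc(CN(C)C(CC(=O)O)c2ccc(Cl)cc2)ccc1OCCn1c(=O)ccn(C)c1=O`: 68%

In an ADME assay on liver (Mus musculus) for metabolic stability, read by LC-MS, using microsomes and NADPH (a lower number here means that less of the compound is left, a higher number that more of the compound is left), compound 3 gives 68%. This lies within the scatter of compound 2 at 69% and clearly above compound 1 at 52%.

Compound 4 `Cc1cc(CN(C2CCC2)C(CC(=O)O)c2ccc(Cl)cc2)ccc1OCCn1c(=O)ccn(C)c1=O` departs from compound 3 by one change: cyclobutyl in place of methyl on an amine nitrogen.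

Among the compounds with values here, only one step has been measured, a number 17 percentage points higher from compound 1 to compound 2 (beyond the scatter). It goes with the fact that one of compounds 1 and 2 is drawn with a defined configuration and the other without, at the place where they differ, so it concerns a drawn configuration and not the group on the amine nitrogen. It offers a sense of how large a modest step is in this assay, but no direction for this change.

The expectation therefore stays close to compound 3 at 68%, with a wide margin and a slight allowance downward. The expected step is a number 8 percentage points lower from compound 3 to compound 4 (within the scatter), which would be small and not clearly beyond the scatter. For compound 4 the estimated value is 60%, with an expected range from 42% to 76%.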

Compound 4, percent of the compound remaining in the Mus musculus assay: 22%
Beside the measured number, compound 4's estimate is 38 percentage points above it; the whole stated range lies above it.
By their numbers in the Mus musculus assay, from the lowest: compound 4; then compound 1; then compounds 3 and 2 (each within the scatter of the next).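

In the Mus musculus assay compound 3 gives 68% and compound 4 gives 22%. Within the data shown here, the group on this amine nitrogen matters strongly in the Mus musculus assay: cyclobutyl in place of methyl gives a number 46 percentage points lower from compound 3 to compound 4 (beyond the scatter), the first measured step that concerns a group and not a drawn configuration. In a physicochemical assay for solubility, at pH 1.1 (a lower number here means a less soluble compound, a higher number a more soluble compound), compound 3 gives 3000000 nM and compound 4 gives 3000000 nM. In the physicochemical assay the same change gives no change at the digits printed from compound 3 to compound 4 (within the scatter), so the two read-outs part at this position. Nothing in the data at hand accounts for the size of the step in compound 4.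

As far as these compounds go, whether ethyl or cyclopropyl on the same nitrogen would read nearer to compound 3 or nearer to compound 4 stays open, and so does whether the step follows ring size, ring presence or the number of carbons. From the compounds shown here alone, compounds 3 and 4 are both drawn without a configuration at their stereocentre, and how a defined one would read for either is also open.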